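A few compounds are considered here, and "the series" means these few. Any claim that something is new, unique, unknown or untested is made for them only; others in the source may bear on it.

Three measured compounds share one core and differ only in the aromatic ring attached to the amide carbonyl. Compound 3 `O=C(Nc1nnc(-c2ccc(Cl)cc2)s1)c1ccccc1F` carries a 2-fluorophenyl group there, and in a functional assay on the whole organism (integument) for inhibition, with Chilo suppressalis as the target, read by scintillation counting, with a stated time of 72 h (a lower number here means a stronger inhibitor, a higher number a weaker inhibitor), compound 3 gives 724 nM. Compound 2 `Cc1cccc(C)c1C(=O)Nc1nnc(-c2ccc(Cl)cc2)s1`, with two methyl groups on that ring instead, gives 69.2 nM, so compound 3 stands at the highest of the two numbers, and the gap between them lies beyond the scatter. Compound 1 `O=C(Nc1nnc(-c2ccc(Cl)cc2)s1)c1c(F)cccc1F`, with a second fluoro, reaches only the limit of the assay and gives > 5010 nM; this is a limit, not a number (the limit of > 5010 nM in this assay, at which 1 of the 3 values shown sits). Taking one fluoro away gives an at least 6.9-fold lower number from compound 1 to compound 3 (0.84 log units; beyond the scatter).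

Compound 4 `O=C(Nc1nnc(-c2ccc(Cl)cc2)s1)c1ccccc1I` is the next step: iodo in place of fluoro on an aromatic carbon. Going by the values given here, no measured pair exchanges one halogen for another, so the only guidance is that the ring tolerates a change at this position. A small lowering of the number is therefore expected, a 1.8-fold lower number from compound 3 to compound 4 (0.26 log units; within the scatter), and compound 4 is estimated at 400 nM, within 100 nM to 1600 nM.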

Compound 4, half-maximal inhibitory concentration: > 5010 nM
Compound 4 ended at the assay's limit; the forecaster's own chance of this, stated with the estimate: 5%; at least 12-fold (1.09 log units) between middle value and limit.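

Exchanging the fluoro of the 2-fluorophenyl group for iodo gives an at least 6.9-fold higher number from compound 3 to compound 4 (0.84 log units; beyond the scatter), so at this ring position the identity of the halogen matters, and not only whether a halogen is present. The earlier step from compound 1 to compound 3 changed a fluoro to a hydrogen, whereas this one exchanges one halogen for another on the same aromatic carbon. For compound 4, > 5010 nM is a limit and not a number, and it is not the only such value in the set: the limit of > 5010 nM in this assay, at which 2 of the 4 values shown sit.

The compounds shown leave open how a bromo or a methoxy group on this same carbon would read in this assay. From the compounds shown here alone, an amine or a single methyl group there is equally open, so two halogens alone set no trend for this position.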